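A few compounds are considered here, and "the series" means these few. Any claim that something is new, unique, unknown or untested is made for them only; others in the source may bear on it.

Within the data shown here, in a functional assay on HepG2 cells (Homo sapiens) for inhibition, read by MTT assay, with a stated time of 24 h (a lower number here means a stronger inhibitor of growth, a higher number a weaker inhibitor of growth), two compounds have numbers so far. Compound 1 `COc1ccc2c(c1)c(-c1nc3ccccc3n1C(=O)c1ccccc1)cn2C` gives 37900 nM, and compound 2 `COc1cccc(C(=O)n2c(-c3cn(C)c4ccc(OC)cc34)nc3ccccc32)c1` gives 11700 nM, the lower of the two and so the stronger inhibitor of growth. The next structure, compound 3 `COc1ccc2c(c1)c(-c1nc3ccccc3n1C(=O)c1ccccc1Br)cn2C`, changes one piece of compound 2: 2-bromophenyl in place of 3-methoxyphenyl on a carbonyl carbon.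

Among the measured compounds shown here, only one measured step bears on this change: a 3.2-fold lower number from compound 1 to compound 2 (0.51 log units; beyond the scatter), modest but beyond the scatter, where methoxy took the place of hydrogen on an aromatic carbon. Compound 3 no longer carries that methoxy, which points back towards the higher number of compound 1, 37900 nM. For the measured compounds named here, no measured compound carries bromine, however, so the data cannot show what it adds, and it could pull either way. A small move towards a higher number is therefore expected, probably no larger than the scatter. The expected change is a 1.7-fold higher number from compound 2 to compound 3 (0.23 log units; within the scatter). For compound 3, the estimated value is 20000 nM, with an expected range from 7000 nM to 55000 nM.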

Compound 3, concentration for 50% growth inhibition: 54200 nM
The estimate for compound 3 lay 2.7-fold (0.43 log units) below the measured number; low and high end bracket the measured number.
By their numbers in this assay, from the lowest: compound 2; then compounds 1 and 3 (each within the scatter of the next).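

In this assay, the group on the carbonyl carbon now has a second substituted phenyl to compare: 2-bromophenyl in place of 3-methoxyphenyl gives a 4.6-fold higher number from compound 2 to compound 3 (0.67 log units; beyond the scatter), which leaves compound 2 as the strongest inhibitor of growth among the three. Bromo in place of hydrogen on an aromatic carbon gives a 1.4-fold higher number from compound 1 to compound 3 (0.16 log units; within the scatter), so compound 1 and compound 3 cannot be told apart here, and of the two substituents tried on this phenyl ring, only the methoxy of compound 2 goes with a number clearly separated from that of the unsubstituted compound. No measurement is available that would explain this difference between methoxy and bromo.

The compounds shown leave open whether the lower number of compound 2 is particular to methoxy or would also come with another group on the phenyl ring, such as an amine, a carboxylic acid or a longer ether chain. Even compound 2 gives 11700 nM, so whether any group on this carbonyl can bring the number much lower also remains open.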